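Phenyl for Furanylmethyl: Expected Tolerance of Compound 3

A few compounds are considered here, and "the series" means these few. Any claim that something is new, unique, unknown or untested is made for them only; others in the source may bear on it.

Compound 1 `COc1cccc(CN2C(=O)CN(C(=O)c3cc4cc(OC)ccc4o3)C[C@@H]2CCc2ccccc2)c1` and compound 2 `COc1ccc2[nH]c(C(=O)N3CC(=O)N(Cc4ccoc4)[C@@H](Cc4ccccc4)C3)cc2c1` share a core and were both tested in an ADME assay on Vero cells (Chlorocebus sabaeus) for cytotoxicity, with a stated time of 7 days; a lower number here means that less compound is tolerated, a higher number that more compound is tolerated. In this assay compound 1 gives 4500 nM. For compound 2 only a limit is known: in this assay compound 2 reads > 10000 nM, which is a limit of the assay and not a number. Compound 2 therefore stands at the tolerated end of the two values shown (the limit of > 10000 nM in this assay, at which 1 of the 2 values shown sits). Compound 3 `COc1ccc2[nH]c(C(=O)N3CC(=O)N(c4ccccc4)[C@@H](Cc4ccccc4)C3)cc2c1` has not yet been measured. It differs from compound 2 in one place: phenyl in place of (furan-3-yl)methyl on an amide-type nitrogen in a ring. Within the data shown here, no measured pair makes this same change, so the expectation rests on the two values alone. The step expected here is a step that the limit leaves unreadable from compound 2 to compound 3, a change not resolved beyond the scatter, since compound 2 already sits at the limit (the limit of > 10000 nM in this assay, at which 1 of the 2 values shown sits). Compound 3 is expected to give 12000 nM in this assay, within 5000 nM to 30000 nM.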

Compound 3, half-maximal cytotoxic concentration: > 30000 nM
Compound 3: a limit, no number; the forecaster's own chance of this, stated with the estimate: 60%; at least 2.5-fold (0.39 log units) between middle value and limit.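

Among these compounds, compound 2 and compound 3 both read as limits of the assay and not as numbers, and no step from one to the other can be read. The compounds shown leave open whether phenyl and (furan-3-yl)methyl on the amide-type nitrogen differ at all in this assay.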